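The source may report more compounds than this note shows. Statements on the series, on what has been measured and on what is new or still open speak of the compounds shown alone.

Working notes on an N-acylated threonine octylamide series; the acyl group on the carbonyl carbon whose other neighbour is the amide-type nitrogen is the only point of variation.

Compound 1 `CCCCCCCCNC(=O)[C@@H](NC(=O)c1ccccc1)[C@@H](C)O` carries phenyl on that carbonyl carbon; in a functional assay on A-431 cells (Homo sapiens) for cytotoxicity, read by MTT assay, with a stated time of 48 h (on this read-out lower numbers stand for stronger inhibition and higher numbers for weaker inhibition), compound 1 gives 61300 nM. Compound 2 `CCCCCCCCNC(=O)[C@@H](NC(=O)c1ccco1)[C@@H](C)O` carries furan-2-yl, and in this assay compound 2 gives 64500 nM. Compound 3 `CCCCCCCCNC(=O)[C@@H](NC(=O)c1cccs1)[C@@H](C)O` carries thiophen-2-yl, and in this assay compound 3 gives 32200 nM. Compound 3 sits at the low end of the three numbers, yet the steps to it are a 1.9-fold lower number from compound 1 to compound 3 (0.28 log units; within the scatter) and a 2.0-fold lower number from compound 2 to compound 3 (0.30 log units; within the scatter), neither beyond the scatter, and a 1.1-fold higher number from compound 1 to compound 2 (0.02 log units; within the scatter) is likewise flat. The three measured steps therefore agree: swapping one aromatic group for another on this carbonyl carbon has not moved the read-out noticeably.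

Compound 4 `CCCCCCCCNC(=O)[C@@H](NC(=O)/C=C/c1ccccc1)[C@@H](C)O` introduces a different kind of group: 2-phenylethenyl in place of thiophen-2-yl on a carbonyl carbon. Among the measured compounds shown here, no measured step covers an extension of the acyl group by a non-aromatic double bond, so the expectation rests only on the flat aryl swaps around compound 3. On that basis compound 4 is expected to show no step beyond the scatter, a 1.0-fold lower number from compound 3 to compound 4 (0.00 log units; within the scatter). Compound 4 is thus estimated at 32000 nM in this assay, within a range of 10000 nM to 100000 nM.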

Compound 4, half-maximal inhibitory concentration: 36000 nM
Compound 4: middle estimate off by 1.1-fold (0.05 log units), on the low side; measured number inside the range.
By their numbers in this assay, from the lowest: compounds 3, 4, 1 and 2 (each within the scatter of the next).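

In this assay the change to 2-phenylethenyl on this carbonyl carbon stays within the scatter against all three earlier groups: a 1.1-fold higher number from compound 3 to compound 4 (0.05 log units; within the scatter); a 1.8-fold lower number from compound 2 to compound 4 (0.25 log units; within the scatter); and a 1.7-fold lower number from compound 1 to compound 4 (0.23 log units; within the scatter). The earlier steps shown here covered only swaps of one aromatic group for another directly on the carbonyl carbon, and the flat picture at this position now also takes in a group that brings 1 double bond outside aromatic rings and 8 heavy atoms. No measured information is at hand that bears on why the read-out stays flat across these four groups.

As far as these compounds go, all four compounds share the octyl chain and the rest of the core, so it stays open whether any group on this carbonyl carbon can move the read-out beyond the scatter, and whether the octyl chain matters more than the acyl group does. An aminomethyl group, a carboxylic acid or a long saturated alkyl chain in place of 2-phenylethenyl would test the first point, and a shorter or longer chain in place of octyl would test the second.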